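Removing one fluorine from a sulfonamide aryl ring

A few compounds are considered here, and "the series" means these few. Any claim that something is new, unique, unknown or untested is made for them only; others in the source may bear on it.

Measured so far:
Compound 1, `CCOC(=O)c1cnc2ccc(-c3cnc(OC)c(NS(=O)(=O)c4ccc(F)cc4F)c3)cn12`: 300 nM
Compound 2, `COc1ncc(-c2ccc3ncc(C(=O)O)n3c2)cc1NS(=O)(=O)c1ccc(F)cc1F`: 750 nM
Compound 3, `CCOC(=O)c1cn2cc(-c3cnc(OC)c(NS(=O)(=O)c4ccc(F)cc4)c3)ccc2n1`: > 20000 nM

In a functional assay on SK-HEP1 cells (Homo sapiens) for antiproliferative activity, read by sulforhodamine B assay, with a stated time of 72 h (on this read-out lower numbers stand for stronger inhibition and higher numbers for weaker inhibition), compound 1 gives 300 nM, the lowest of the two numbers reported. Its nearest neighbour is compound 2, which in this assay gives 750 nM, a difference of a 2.5-fold higher number from compound 1 to compound 2 (0.40 log units; beyond the scatter). For compound 3 this assay reports only a limit, > 20000 nM, and not a number, and indeed (the limit of > 20000 nM in this assay, at which 1 of the 3 values shown sits).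

Compound 4, `CCOC(=O)c1cnc2ccc(-c3cnc(OC)c(NS(=O)(=O)c4ccc(F)cc4)c3)cn12`, differs from compound 1 by a single change: hydrogen in place of fluoro on an aromatic carbon. For the measured compounds named here, the only measured step, that from compound 1 to compound 2, alters the ester, not the sulfonamide aryl ring, so it gives no direct guide to what losing a fluoro group does. Compound 3 carries the same 4-fluorophenyl group as compound 4, but its core is joined differently from that of compound 1, so its limit cannot be read as the effect of the fluorine alone. Going by the values given here, with no step that bears on this change, the expectation is modest: compound 4 is estimated at 700 nM, with a range from 250 nM to 3000 nM, which means an expected step of a 2.3-fold higher number from compound 1 to compound 4 (0.37 log units; beyond the scatter), a weakening that may stay within the scatter.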

Compound 4, half-maximal inhibitory concentration: > 20000 nM
Compound 4: no number, only a limit; the forecaster's own chance of this, stated with the estimate: 10%; middle value at least 28-fold (1.45 log units) away from the limit.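

For the compounds shown here, this single fluoro group turns out to matter far more than the earlier compounds could show: going from the 2,4-difluorophenyl to the 4-fluorophenyl sulfonamide gives an at least 66-fold higher number from compound 1 to compound 4 (1.82 log units; beyond the scatter). That is a much larger change than the one at the ester, where replacing ethyl with hydrogen gives a 2.5-fold higher number from compound 1 to compound 2 (0.40 log units; beyond the scatter), so this aryl position is far less forgiving in this assay. Compound 4 yields only a limit rather than a number, the same limit seen for compound 3, which also carries the 4-fluorophenyl group, while both compounds shown with the 2,4-difluorophenyl group give numbers: the limit of > 20000 nM in this assay, at which 2 of the 4 values shown sit.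

The compounds shown do not tell whether fluoro is specifically required at this position, ortho to a large group, or whether a chloro or methyl group there would also retain activity. They also leave open whether the fluoro group that remains in compound 4 matters in the same way, since no 2-fluorophenyl or unsubstituted phenyl sulfonamide appears among them.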